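Swapping furan for thiophene in a coumarin-linked dienone

This account rests on a few compounds, and the source may have more. Where it says the series, first, only, none or still open, it means among the compounds named here.

Of the compounds shown here, three have been tested in a functional assay on COLO 205 cells (Homo sapiens) for inhibition, read by sulforhodamine B assay, with a stated time of 48 h, tested at 50 uM; a lower number here means less inhibition of growth, a higher number more inhibition of growth at the concentration tested. Compound 1 `COc1cc(/C=C/C(=O)/C=C/c2cccs2)ccc1OCc1cn(CCCCCOc2cc(=O)oc3ccccc23)nn1` gives 30%, compound 2 `COc1cc(/C=C/C(=O)/C=C/c2ccco2)ccc1OCc1cn(CCCCOc2cc(=O)oc3ccccc23)nn1` gives 43%, and compound 3 `COc1cccc(/C=C/C(=O)/C=C/c2ccc(OCc3cn(CCCOc4cc(=O)oc5ccccc45)nn3)c(OC)c2)c1` gives 52%. Among these three numbers compound 2 sits second highest: the number of compound 3 lies within the usual scatter of repeated measurements of the number of compound 2, while the number of compound 1 lies beyond that scatter on the lower side.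

Compound 4 `COc1cc(/C=C/C(=O)/C=C/c2cccs2)ccc1OCc1cn(CCCCOc2cc(=O)oc3ccccc23)nn1` has not yet been measured in this assay. It differs from compound 2 in one place: thiophen-2-yl in place of furan-2-yl on a double-bonded chain carbon bound to a double-bonded chain carbon. Among the compounds with values here, compound 1 also carries thiophen-2-yl, but it differs from compound 2 in more than one place, so no single clean step connects it to either compound 2 or compound 4.

Within the data shown here, only the pair of numbers of compound 1 and compound 2 offers any hint, and it points modestly downward. The step of a number 7 percentage points lower from compound 2 to compound 4 (within the scatter) is therefore expected to be small and in the direction of less inhibition, though it may well stay within the scatter. Compound 4 is estimated at 36%, with a likely range from 20% to 52%.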

Compound 4, percent growth inhibition at one concentration: 40%
Compound 4: middle estimate off by 4 percentage points, on the low side; the measured number falls inside the stated range.
By their numbers in this assay, from the lowest: compounds 1, 4, 2 and 3 (each within the scatter of the next, the first and the last beyond it).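

In this assay there is a number 3 percentage points lower from compound 2 to compound 4 (within the scatter) when thiophen-2-yl takes the place of furan-2-yl on a double-bonded chain carbon bound to a double-bonded chain carbon. Within the data shown here, this is the first clean, single-change comparison at this position, and it shows that the two five-membered aromatic rings, one holding oxygen and the other sulfur, cannot be told apart here at the concentration tested. Any real difference between them is too small for this measurement to detect.

From the compounds shown here alone, it remains open whether a different group at this position, such as a pyridine ring or a ring carrying a carboxylic acid, would shift growth inhibition beyond the scatter. Nothing available here explains the result in terms of cause.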